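Three anilide analogues at the cytotoxicity limit, and a fourth

This account rests on a few compounds, and the source may have more. Where it says the series, first, only, none or still open, it means among the compounds named here.

Compound 1 `O=C(Nc1ccccc1)c1cccc(/C=C2\CC(=O)N(c3ccccc3)C2=O)c1`: > 100000 nM
Compound 2 `Cc1cccc(NC(=O)c2cccc(/C=C3\CC(=O)N(c4ccccc4)C3=O)c2)c1`: > 100000 nM
Compound 3 `COc1ccc(NC(=O)c2cccc(/C=C3\CC(=O)N(c4ccccc4)C3=O)c2)c(C)c1`: > 100000 nM

In an ADME assay on HCT-116 cells (Homo sapiens) for cytotoxicity, read by MTT assay, with a stated time of 72 h (a lower number here means a stronger inhibitor, a higher number a weaker inhibitor), compound 1 gives only a limit, > 100000 nM. Compound 2 likewise gives a limit, > 100000 nM. Compound 3 also gives a limit, > 100000 nM. Compound 2 and compound 1 differ by hydrogen in place of methyl on an aromatic carbon, and the step that the two limits leave unreadable from compound 2 to compound 1 cannot be sized because of the limit of > 100000 nM in this assay, at which 3 of the 3 values shown sit. Compound 3 differs from compound 2 by 4-methoxy-2-methylphenyl in place of 3-methylphenyl on an amide-type nitrogen.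

Compound 4 `COc1ccc(NC(=O)c2cccc(/C=C3\CC(=O)N(c4ccccc4)C3=O)c2)cc1` awaits measurement in this assay. It differs from compound 3 by hydrogen in place of methyl on an aromatic carbon, the same kind of change as from compound 2 to compound 1, though here the place is ortho to a large group and meta to a methoxy group rather than meta to a large group. Compound 3 shows only the limit > 100000 nM. Compound 4 is therefore expected to remain at that limit, a step that the limit leaves unreadable from compound 3 to compound 4, with an estimate of 150000 nM, between 60000 nM and 400000 nM.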

Compound 4, half-maximal inhibitory concentration: > 100000 nM
Compound 4: a limit, no number (the forecaster's own chance of this, stated with the estimate: 85%); the middle value lies beyond the limit too.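

Compound 4 also gives only a limit, so no step to it from compound 1, compound 2 or compound 3 can be read, because all four values sit at the same limit: the limit of > 100000 nM in this assay, at which 4 of the 4 values shown sit.

The compounds shown leave open whether any of the four differs from the others in this assay.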